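From Dichlorophenyl Ethenyl to Methyl-Oxazolyl Methoxy on the Carbonyl

A few compounds are considered here, and "the series" means these few. Any claim that something is new, unique, unknown or untested is made for them only; others in the source may bear on it.

In an ADME assay on Caco-2 cells (Homo sapiens) for permeability, in the apical to basolateral direction, with a stated time of 90 min, tested at 10 uM (a lower number here means that the compound crosses the layer more slowly, a higher number that the compound crosses the layer faster), compound 1 (`O=C(NC[C@@H]1[C@H]2CN(C(=O)/C=C/c3cc(Cl)cc(Cl)c3)C[C@@H]12)c1ccc2[nH]c(=O)oc2c1`) gives 38 10^-6 cm/s and compound 2 (`N#Cc1cc(COC(=O)N2C[C@@H]3[C@@H](CNC(=O)c4ccc5[nH]c(=O)oc5c4)[C@@H]3C2)cc(OC(F)(F)F)c1`) gives 44 10^-6 cm/s, two numbers within the usual scatter of each other. Compound 3 (`Cc1cc(COC(=O)N2C[C@@H]3[C@@H](CNC(=O)c4ccc5[nH]c(=O)oc5c4)[C@@H]3C2)no1`) has not yet been measured. It carries (5-methyl-1,2-oxazol-3-yl)methoxy in place of 2-(3,5-dichlorophenyl)ethenyl on a carbonyl carbon. Going by the values given here, no pair of measured compounds differing in one place is available, so the expectation rests on thin evidence. Compound 2 also lacks the 2-(3,5-dichlorophenyl)ethenyl and gives 44 10^-6 cm/s, so no large drop is expected from that loss alone. Only a modest fall, within the scatter, is expected, and the estimated step is a 1.4-fold lower number from compound 1 to compound 3 (0.13 log units; within the scatter). For compound 3 the estimated value is 28 10^-6 cm/s, with an expected range from 13 10^-6 cm/s to 50 10^-6 cm/s.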

Compound 3, apparent permeability: 2 10^-6 cm/s
Compound 3: the middle estimate sits 14-fold (1.15 log units) above what was measured, and the stated range ends above it.
By their numbers in this assay, from the lowest: compound 3; then compounds 1 and 2 (each within the scatter of the next).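

In this assay the carbonyl carbon on the ring amide-type nitrogen proves far from indifferent to what it carries: the exchange brings a 19-fold lower number from compound 1 to compound 3 (1.28 log units; beyond the scatter), a large step that the first two compounds gave no sign of. The 2-(3,5-dichlorophenyl)ethenyl can be lost without a low number, since compound 2 lacks it and gives 44 10^-6 cm/s, so the outcome here goes with the (5-methyl-1,2-oxazol-3-yl)methoxy that enters. No measurement at hand explains the step.

Which part of the entering group goes with the low number remains open, whether the five-membered aromatic ring, its hetero atoms or its methyl. A plain phenylmethoxy or a pyridinylmethoxy at this carbonyl carbon could show whether the number stays near that of compound 2 or falls towards that of compound 3.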